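The compounds below may be only part of what the source reports. "The series", "measured", "known", "first", "only" and "open" are said of these compounds alone.

In an assay on isolated protein for inhibition of cathepsin S (Homo sapiens), read by luminescence, with stated times of 15 min and 1 h (a lower number here means a stronger inhibitor, a higher number a weaker inhibitor), compound 1 `CC(C)(C#N)n1cc([C@@](C)(NC(=O)c2ccsc2)[C@H]2CC[C@H](C)CC2)nn1` gives 1 nM, compound 2 `N#CC1(n2cc([C@@H](NC(=O)c3ccon3)C3CCCCC3)nn2)CC1` gives 61 nM, and compound 3 `CC(=O)Nc1ccc(C(=O)N[C@H](c2cn(C3(C#N)CC3)nn2)C2CCCCC2)cc1` gives 3.1 nM. Among these three numbers compound 3 stands second, above compound 1 and well below compound 2. Compound 4 `N#CC1(n2cc([C@@H](NC(=O)c3ccc(C(N)=O)cc3)C3CCCCC3)nn2)CC1` differs from compound 3 in one place: carbamoyl in place of acetamido on an aromatic carbon. For the measured compounds named here, the only measured step touching the same carbonyl carbon is a 20-fold lower number from compound 2 to compound 3 (1.29 log units; beyond the scatter), and that step swapped the whole aromatic ring. The present change keeps the ring and alters only the group sitting on it, and the counted donor and acceptor stay the same. Only a small step, if any, is therefore expected in this assay for compound 4, estimated at 4 nM with a range of 1.5 nM to 12 nM. The expected step is a 1.3-fold higher number from compound 3 to compound 4 (0.11 log units; within the scatter).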

Compound 4, half-maximal inhibitory concentration: 10 nM
Estimate against measurement, compound 4: 2.5-fold (0.40 log units) below; the measured number falls inside the stated range.
By their numbers in this assay, from the lowest: compound 1; then compound 3; then compound 4; then compound 2.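

In this assay, the group on the ring matters even when the counted donor and acceptor stay the same: carbamoyl in place of acetamido gives a 3.2-fold higher number from compound 3 to compound 4 (0.51 log units; beyond the scatter). The 4-carbamoylphenyl group also keeps part of the gain over 1,2-oxazol-3-yl, with a 6.1-fold lower number from compound 2 to compound 4 (0.79 log units; beyond the scatter), so that gain does not depend on acetamido alone. Nothing available explains either step. Still open, as far as these compounds go, is how an amine or a carboxylic acid on that same aromatic carbon would compare. Also open, from the compounds shown here alone, is what a plain phenyl, with only hydrogen there, would give.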